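The source may report more compounds than this note shows. Statements on the series, on what has been measured and on what is new or still open speak of the compounds shown alone.

Of the compounds shown here, three that share one core have been measured in a functional assay on MCF7 cells (Homo sapiens) for cytotoxicity, read by MTT assay, with a stated time of 24 h; a higher number here means a weaker inhibitor, a lower number a stronger inhibitor. Compound 1 `COc1cc2ncnc(Nc3cccc(C(F)(F)F)c3)c2cc1OCCCSc1nc2ccccc2s1` gives 4050 nM, compound 2 `CCc1cc(Br)ccc1Nc1ncnc2cc(OC)c(OCCCSc3nc4ccccc4s3)cc12` gives 5870 nM, and compound 3 `COc1cc2ncnc(Nc3cccc(C(F)(F)F)c3)c2cc1OCCCSc1nc2ccccc2o1` gives 4030 nM. Compound 3 thus carries the lowest number of the three, although its gaps to compound 1 and to compound 2 both fall within the scatter. Compound 4 `CCc1cc(Br)ccc1Nc1ncnc2cc(OC)c(OCCCSc3nc4ccccc4o3)cc12` differs from compound 3 by 4-bromo-2-ethylphenyl in place of 3-(trifluoromethyl)phenyl on a nitrogen on an aromatic ring. The same exchange appears among the measured pairs as a 1.4-fold higher number from compound 1 to compound 2 (0.16 log units; within the scatter), while the exchange that separates compound 3 from compound 1 reads a 1.0-fold lower number from compound 1 to compound 3 (0.00 log units; within the scatter). A comparably small step in this assay, or none beyond the scatter, is therefore expected, namely a 1.4-fold higher number from compound 3 to compound 4 (0.16 log units; within the scatter). Compound 4 is estimated at 5800 nM, with a range from 3000 nM to 11000 nM.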

Compound 4, half-maximal inhibitory concentration: 17300 nM
The estimate for compound 4 lay 3.0-fold (0.47 log units) below the measured number, and the stated range ends below it.
By their numbers in this assay, from the lowest: compounds 3, 1 and 2 (each within the scatter of the next); then compound 4.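

With 1,3-benzoxazol-2-yl on the sulfur, 4-bromo-2-ethylphenyl in place of 3-(trifluoromethyl)phenyl gives a 4.3-fold higher number from compound 3 to compound 4 (0.63 log units; beyond the scatter) and so takes this exchange on the nitrogen beyond the scatter, which the earlier pair did not show: the same change on two cores in this assay, a 1.4-fold higher number (0.16 log units; within the scatter) from compound 1 to compound 2 and a 4.3-fold higher number (0.63 log units; beyond the scatter) from compound 3 to compound 4, 3.0-fold (0.47 log units) apart, beyond the scatter of two such steps
Likewise, 1,3-benzoxazol-2-yl in place of 1,3-benzothiazol-2-yl now gives a 2.9-fold higher number from compound 2 to compound 4 (0.47 log units; beyond the scatter) with 4-bromo-2-ethylphenyl on the nitrogen: the same change on two cores in this assay, a 1.0-fold lower number (0.00 log units; within the scatter) from compound 1 to compound 3 and a 2.9-fold higher number (0.47 log units; beyond the scatter) from compound 2 to compound 4, 3.0-fold (0.47 log units) apart, beyond the scatter of two such steps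
The size of each change therefore depends on which group sits at the other place.

Whether the bromine or the ethyl accounts for this remains open. So does whether a plain phenyl or an amine-bearing phenyl on the nitrogen would show the same dependence.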